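Chain Length, Ring Substituent and Cytotoxicity in RD Cells

This account rests on a few compounds, and the source may have more. Where it says the series, first, only, none or still open, it means among the compounds named here.

Measured so far:
compound 1 `CC[C@H](CCn1cncn1)c1ccc(OC)cc1`: 118 ug/mL
compound 2 `CCC[C@H](CCn1cncn1)c1ccc(OC)cc1`: 59.3 ug/mL
compound 3 `CCCC[C@H](CCn1cncn1)c1ccc(Cl)cc1`: 20.3 ug/mL

In an ADME assay on RD cells (Homo sapiens) for cytotoxicity, read by MTT assay, with a stated time of 3 days (on this read-out higher numbers stand for lower toxicity in this test and lower numbers for higher toxicity in this test), compound 3 gives the lowest of the three numbers: compound 2 sits a clear step higher, and compound 1 higher still, both gaps beyond the scatter. Compound 4 `CCCC[C@H](CCn1cncn1)c1ccc(OC)cc1` is the next compound and has not yet been measured. It differs from compound 3 by methoxy in place of chloro on an aromatic carbon. For the measured compounds named here, no measured step swaps chloro for methoxy directly, so what the two groups do to the read-out is unknown here. Going by the values given here, the only measured step, a 2.0-fold lower number from compound 1 to compound 2 (0.30 log units; within the scatter), lengthens the chain by one carbon and stays within the scatter. Compound 4 carries the same methoxy as compounds 1 and 2 with a chain one carbon longer than compound 2, so compound 4 is expected to land between compound 2 and compound 3, as a step of a 1.5-fold higher number from compound 3 to compound 4 (0.17 log units; within the scatter). The estimate for compound 4 is 30 ug/mL, within 12 ug/mL to 70 ug/mL.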

Compound 4, half-maximal cytotoxic concentration: 28.3 ug/mL
Compound 4: middle estimate off by 1.1-fold (0.03 log units), on the high side, within the range that was stated.
By their numbers in this assay, from the lowest: compounds 3 and 4 (each within the scatter of the next); then compounds 2 and 1 (each within the scatter of the next).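

At this position on an aromatic carbon, para to a large group, swapping chloro for methoxy leaves the number in this assay within the scatter (a 1.4-fold higher number from compound 3 to compound 4 (0.14 log units; within the scatter)), so the two groups cannot be told apart on this chain. With methoxy held fixed, the chain carries the clearer signal: adding a methyl here gives a modest change beyond the scatter (a 2.1-fold lower number from compound 2 to compound 4 (0.32 log units; beyond the scatter)), as does adding an ethyl (a 4.2-fold lower number from compound 1 to compound 4 (0.62 log units; beyond the scatter)), whereas the earlier methyl step stayed within it. Nothing shown here offers an explanation for these differences.

As far as these compounds go, whether chloro and methoxy also match on the shorter chains of compound 1 and compound 2 remains open. From the compounds shown here alone, what an amine or a carboxylic acid at this aromatic carbon would do is also open, as is whether a longer chain would continue the trend.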